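A few compounds are considered here, and "the series" means these few. Any claim that something is new, unique, unknown or untested is made for them only; others in the source may bear on it.

Of the compounds shown here, two of this small series have been tested, and neither gave a measurable dose. Compound 1, `Nc1nnc(-c2ccccc2OCc2ccc(Cl)cc2)o1`, was examined in a functional assay on the whole organism with Mus musculus as the target; a lower number here means that less compound is needed, a higher number that more compound is needed for the effect. In this assay compound 1 reached only the limit of the assay, > 100 mg/kg, and not a number. Compound 2, `Sc1nnc(-c2ccccc2OCc2ccccc2)o1`, shares the same core with a different group on the oxadiazole ring. In this assay compound 2 likewise stopped at the limit, > 100 mg/kg, so no figure is known for it. Compound 2 therefore stands at the limit of > 100 mg/kg in this assay, at which 2 of the 2 values shown sit, which means every value gathered so far is a limit and no ordering between the two compounds can be read from them.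

Compound 3, `CCSc1nnc(-c2ccccc2OCc2ccccc2)o1`, differs from compound 2 by ethyl in place of hydrogen on a sulfur. Among the compounds with values here, no measured step between any two compounds is available, so the size and direction of this change cannot be drawn from the data. With both neighbours at the limit, the step that the limit leaves unreadable from compound 2 to compound 3 is expected to stay within the usual scatter. Compound 3 is thus estimated to give about 150 mg/kg in this assay, somewhere between 40 mg/kg and 600 mg/kg, with a considerable chance that only a limit is reported again.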

Compound 3, dose for half-maximal effect: > 100 mg/kg
Compound 3: a limit, no number (the forecaster's own chance of this, stated with the estimate: 65%); the middle value is on the limit's open side.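

Within the data shown here, compound 3, like compound 2, ended at a limit in this assay and gave no number, so no step from compound 2 to compound 3 can be read. The compounds shown leave open whether ethyl in place of hydrogen on a sulfur changes the dose at all, and whether any compound of this series reaches a measurable dose in this assay at all.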